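Swapping a chloro group for a piperazine on a urea series

The source may report more compounds than this note shows. Statements on the series, on what has been measured and on what is new or still open speak of the compounds shown alone.

Three urea compounds sharing one core have been tested in an ADME assay on a cell-free system (plasma, Rattus norvegicus) for protein binding. Compound 1 `CNc1nccc(N2CC[C@H](NC(=O)Nc3ccc(Cl)c(C(F)(F)F)c3)C2)n1` gives 99.7%, compound 2 `CNc1nccc(N2CC[C@H](NC(=O)Nc3ccc(OC(F)(F)F)cc3)C2)n1` gives 98.1%, and compound 3 `CNc1nccc(N2CC[C@H](NC(=O)Nc3ccc(C)c(Cl)c3)C2)n1` gives 98.9%. On these numbers compound 1 leaves the smallest unbound fraction of the three; compound 3 sits nearest to it and compound 2 furthest, and both gaps lie beyond the usual scatter of this assay.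

Compound 4 `CCN1CCN(Cc2ccc(NC(=O)N[C@H]3CCN(c4ccnc(NC)n4)C3)cc2C(F)(F)F)CC1` is not yet measured. It differs from compound 1 in one place: (4-ethylpiperazin-1-yl)methyl in place of chloro on an aromatic carbon. Among the compounds with values here, no measured pair shows this exact change, so no step can be read off. The expectation is a step toward a lower number, beyond the scatter, a 12-fold higher unbound fraction from compound 1 to compound 4 (1.07 log units; beyond the scatter). Compound 4 is therefore estimated at 96.5%, within a range of 92% to 99%.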

Compound 4, plasma protein binding: 84.2%
Estimate against measurement, compound 4: 4.5-fold (0.65 log units) (unbound fraction) below; the measured number lies below the stated range.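

Putting (4-ethylpiperazin-1-yl)methyl in place of chloro on this aromatic carbon gives a 53-fold higher unbound fraction from compound 1 to compound 4 (1.72 log units; beyond the scatter) in this assay, so a change at this one position can greatly alter how much compound stays free. Within the data shown here, none of the earlier compounds carries a ring-bearing group here. Nothing available explains the size of this step.

The compounds shown leave open which part of the new group matters, and whether a morpholine ring or a simple dimethylamino group at this position would give a similar step.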